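The compounds below may be only part of what the source reports. "The series", "measured", "known", "first", "only" and "open" are said of these compounds alone.

Measured compounds:
- compound 1, `O=C(Nc1cc(C(F)(F)F)cc(C(F)(F)F)c1)c1cc(Br)ccc1O`: 590 nM
- compound 2, `O=C(Nc1cc(C(F)(F)F)cc(C(F)(F)F)c1)c1ccc(Cl)cc1O`: 850 nM
- compound 3, `O=C(Nc1cc(C(F)(F)F)cc(C(F)(F)F)c1)c1cc(F)ccc1O`: 620 nM

In a functional assay on NALM-6 cells (Homo sapiens) for cytotoxicity, read by luminescence and CellTiter-Glo, with a stated time of 3 days (a higher number here means a weaker inhibitor, a lower number a stronger inhibitor), compound 3 stands second highest of the three numbers. Its nearest neighbour is compound 1, at a 1.1-fold higher number from compound 1 to compound 3 (0.02 log units; within the scatter), and its furthest is compound 2, at a 1.4-fold lower number from compound 2 to compound 3 (0.14 log units; within the scatter); both gaps lie within the scatter, so the three compounds cannot be told apart on these numbers. Compound 4, `O=C(Nc1cccc(C(F)(F)F)c1)c1cc(F)ccc1O`, has not yet been measured. It differs from compound 3 in one place: hydrogen in place of trifluoromethyl on an aromatic carbon. The measured steps, a 1.4-fold higher number from compound 1 to compound 2 (0.16 log units; within the scatter), a 1.1-fold higher number from compound 1 to compound 3 (0.02 log units; within the scatter) and a 1.4-fold lower number from compound 2 to compound 3 (0.14 log units; within the scatter), all concern the halogen on the hydroxyphenyl ring and leave the two trifluoromethyl groups untouched, so none of them bears on this change. The data give no footing for the size or direction of the step, and the estimate carries a wide range. Compound 4 is expected to give about 1500 nM, between 500 nM and 5000 nM, which means an expected step of a 2.4-fold higher number from compound 3 to compound 4 (0.38 log units; beyond the scatter).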

Compound 4, half-maximal inhibitory concentration: 1800 nM
Compound 4: middle estimate off by 1.2-fold (0.08 log units), on the low side, and the stated range covers the measured number.
By their numbers in this assay, from the lowest: compounds 1, 3 and 2 (each within the scatter of the next); then compound 4.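

Among the compounds shown here, replacing one trifluoromethyl group with hydrogen on this six-membered aromatic ring gives the first step beyond the scatter: in this assay, there is a 2.9-fold higher number from compound 3 to compound 4 (0.46 log units; beyond the scatter). The halogen changes among compound 1, compound 2 and compound 3 all stayed within the scatter, so this trifluoromethyl position matters in this assay in a way those changes did not show. The data offer no measurement that explains this modest loss of potency.

The compounds shown leave open whether a methyl group, a chlorine atom, a methoxy group or a nitrile at this place would give a number closer to that of compound 3 or of compound 4. They also leave open what replacing the remaining trifluoromethyl group with hydrogen would do.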